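A few compounds are considered here, and "the series" means these few. Any claim that something is new, unique, unknown or untested is made for them only; others in the source may bear on it.

Two compounds share one core and differ only in the aryl group attached to the carbon that carries a double bond to nitrogen. Compound 1 `COc1cc(C(=O)N/N=C/c2c(Cl)cccc2Cl)cc(OC)c1OC` carries a 2,6-dichlorophenyl there, and in a functional assay on BGC-823 cells (Homo sapiens) for antiproliferative activity, read by MTT assay, tested at 1 uM (a lower number here means a weaker effect, a higher number a stronger effect of the compound at the concentration tested), compound 1 gives 0.9%. Compound 2 `COc1cc(C(=O)N/N=C/c2ccc(F)cc2)cc(OC)c1OC` carries a 4-fluorophenyl instead, and in this assay compound 2 gives 50.9%. That single swap produced a number 50 percentage points higher from compound 1 to compound 2 (beyond the scatter), so compound 2 stands highest of the two numbers measured, with compound 1 the nearest and far lower.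

Compound 3 `COc1cc(C(=O)N/N=C/c2ccc(Cl)c(Cl)c2)cc(OC)c1OC` has not yet been measured. It differs from compound 2 in one place: 3,4-dichlorophenyl in place of 4-fluorophenyl on a carbon with a double bond to nitrogen. Within the data shown here, only the step from compound 1 to compound 2 bears on this change, and it was large; it shows that the aryl group on that carbon can move the result strongly, but it compared a 2,6-dichlorophenyl with a 4-fluorophenyl, not a 3,4-dichlorophenyl, so it cannot fix the direction here. A sizeable step either way is possible. Because compound 1 gave 0.9% with its 2,6-dichlorophenyl, some fall is the more cautious expectation. The expected step is a number 15.9 percentage points lower from compound 2 to compound 3 (beyond the scatter). Compound 3 is therefore expected to give about 35%, most likely between 5% and 65%.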

Compound 3, a percentage reported as inhibition, at one concentration (the size of the read-out at that concentration, not a potency): 29.6%
The estimate for compound 3 lay 5.4 percentage points above the measured number; the measured number falls inside the stated range.
By their numbers in this assay, from the lowest: compound 1; then compound 3; then compound 2.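

In this assay, moving from one dichlorophenyl group to another on the carbon with a double bond to nitrogen gives a number 28.7 percentage points higher from compound 1 to compound 3 (beyond the scatter), although 2,6-dichlorophenyl and 3,4-dichlorophenyl are built from the same atoms and differ only in where the chlorines sit. The read-out at this position therefore depends on the arrangement of the groups on the ring and not only on which halogen is present, a distinction that the first pair could not make, as it changed both at once. Replacing 4-fluorophenyl with 3,4-dichlorophenyl gives a number 21.3 percentage points lower from compound 2 to compound 3 (beyond the scatter), which places compound 3 between the other two compounds, though nothing available explains either step.

All three aryl groups shown carry halogens, so it remains open how a plain phenyl, a methoxyphenyl, or a phenyl bearing an amine or a carboxylic acid would behave at this carbon. A 4-chlorophenyl group would also help, as it would separate the effect of exchanging fluorine for chlorine from that of adding a second chlorine.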